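Notes on compound 3: a larger group on the same nitrogen

The source may hold more compounds than are shown below. What is called first, only, known or untested is meant among the compounds shown, and "the series" means these compounds.

In a functional assay on HUVEC cells (Homo sapiens) for inhibition (on this read-out lower numbers stand for stronger inhibition and higher numbers for weaker inhibition), compound 1 `CN(c1ccc(NS(=O)(=O)Cc2ccccc2)cc1)c1ccnc(Nc2cccc(CS(C)(=O)=O)c2)n1` gives 350 nM and compound 2 `CN(c1ccc(NC(=N)Nc2ccccc2)cc1)c1ccnc(Nc2cccc(CS(C)(=O)=O)c2)n1` gives 596 nM, two values that lie within the scatter of each other. For the measured compounds named here, compound 3 `CC(=O)c1ccc(NC(=O)Nc2ccc(N(C)c3ccnc(Nc4cccc(CS(C)(=O)=O)c4)n3)cc2)cc1` has no measurement yet. Its difference from compound 2 is a group of 12 heavy atoms (9 carbon, 1 nitrogen, 2 oxygen; one six-membered aromatic ring of carbon only) in place of a group of 9 heavy atoms (7 carbon, 2 nitrogen; one six-membered aromatic ring of carbon only), on a nitrogen on an aromatic ring, and the entering group is (4-acetylphenyl)carbamoyl. Going by the values given here, the only measured exchange at this place is a 1.7-fold higher number from compound 1 to compound 2 (0.23 log units; within the scatter), a step that does not leave the scatter. Among the compounds with values here, that single step is the whole basis for an expectation, and no measured compound carries the (4-acetylphenyl)carbamoyl group, so the range has to stay wide. The expected change is a 1.5-fold lower number from compound 2 to compound 3 (0.17 log units; within the scatter), which means no step beyond the scatter. For compound 3 the estimated value is 400 nM, with 100 nM to 1500 nM as the expected range.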

Compound 3, half-maximal inhibitory concentration: 2 nM
The estimate for compound 3 lay 200-fold (2.30 log units) above the measured number; measured number below the stated range.
By their numbers in this assay, from the lowest: compound 3; then compounds 1 and 2 (each within the scatter of the next).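

In this assay the group on this nitrogen on an aromatic ring can move the read-out far more than the step from compound 1 to compound 2 showed. With (4-acetylphenyl)carbamoyl the number falls sharply in both comparisons (a 300-fold lower number from compound 2 to compound 3 (2.47 log units; beyond the scatter); a 180-fold lower number from compound 1 to compound 3 (2.24 log units; beyond the scatter)). All three groups carry one six-membered aromatic ring of carbon only, so that ring alone does not separate compound 3 from the other two, and no supporting data bear on the reason for the drop.

The compounds shown leave open whether the acetyl group or the carbamoyl link accounts for the change, as no plain phenylcarbamoyl group stands among them. Also open, going by these compounds, is whether a nitrile, a carboxylic acid or an amine in place of the acetyl group would keep the low number.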